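Fluorine on a Kinase Binder: What to Expect

The source may hold more compounds than are shown below. What is called first, only, known or untested is meant among the compounds shown, and "the series" means these compounds.

Compound 1 `Cn1cnc2c(Sc3ccccc3)ncnc21` is the starting point of this small set. In an assay on isolated protein for inhibition of Rho-associated protein kinase 1 (Homo sapiens), tested at 30 uM (a higher number here means more inhibition at the concentration tested (going by the name of the read-out), a lower number less inhibition), compound 1 gives 6%. Compound 2 `Cn1cnc2c(Sc3ccc(F)cc3)ncnc21` differs from it by fluoro in place of hydrogen on an aromatic carbon; in this assay compound 2 gives 6%, and no change at the digits printed from compound 1 to compound 2 (within the scatter). Compound 3 `Cn1cnc2c(SCc3ccccc3)ncnc21` has a different core, and the difference between its core and that of compound 1 is not broken down here. In this assay compound 3 gives 1%, a number that lies within the scatter of the values of compound 1 and compound 2, so no order among the three can be read from these measurements. Compound 4 `Cn1cnc2c(SCc3ccc(F)cc3)ncnc21` has not yet been measured. It differs from compound 3 by fluoro in place of hydrogen on an aromatic carbon, the same change that separates compound 1 from compound 2, at a place described in the same words. Because no change at the digits printed from compound 1 to compound 2 (within the scatter), a similarly small step is expected here as well: a number 1 percentage points higher from compound 3 to compound 4 (within the scatter). Compound 4 is therefore estimated to give 2% in this assay, most likely somewhere between -4% and 10%.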

Compound 4, a percentage reported as inhibition, at one concentration (the size of the read-out at that concentration, not a potency): 6%
For compound 4 the middle estimate is 4 percentage points below the measured one; measured number inside the range.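

In this assay, among these compounds, fluoro in place of hydrogen on an aromatic carbon gives a number 5 percentage points higher from compound 3 to compound 4 (within the scatter) and so cannot be told apart from no step at all. Set beside the earlier step, the same change looks no different on the two cores, as far as this read-out can tell: the same change on two cores in this assay, no change at the digits printed (within the scatter) from compound 1 to compound 2 and a number 5 percentage points higher (within the scatter) from compound 3 to compound 4, 5 percentage points apart, within the scatter of two such steps. Among the compounds shown here, this shows only that the swap did not lift inhibition beyond the scatter on either core; it does not show that fluoro has a real effect on either one, or that two steps this small follow one shared rule, and it says nothing about a core with much stronger inhibition, where a step would be easier to see.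

The compounds shown leave open whether another group in place of the fluoro, such as an amine or a carboxylic acid, would move the number beyond the scatter. They also leave open whether a longer chain on the sulfur would do so.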